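Methyl on the Ring: From One Core to Another

The compounds below may be only part of what the source reports. "The series", "measured", "known", "first", "only" and "open" are said of these compounds alone.

Compound 1 `CCOC(=O)N(C)CC#CCn1ccnc1` and compound 2 `CCOC(=O)N(C)CC#CCn1cncc1C` share one core. In a functional assay on the whole organism for antagonist activity, with Mus musculus as the target (on this read-out lower numbers stand for an effect already at smaller amounts and higher numbers for an effect only at larger amounts of compound), compound 1 gives 97 mg/kg. In this assay compound 2 gives 66 mg/kg. The change between them is methyl in place of hydrogen on an aromatic carbon, and it brought a 1.5-fold lower number from compound 1 to compound 2 (0.17 log units; within the scatter). Compound 3 `O=C1OCCN1CC#CCn1ccnc1` is built on a second core; the difference between the two cores is not broken down here. In this assay compound 3 gives only a limit of the assay, > 100 mg/kg. This is the limit of > 100 mg/kg in this assay, at which 1 of the 3 values shown sits. Compound 4 `Cc1cncn1CC#CCN1CCOC1=O` has not yet been tested in this assay. For the measured compounds named here, it differs from compound 3 by methyl in place of hydrogen on an aromatic carbon, the same change as the one between compound 1 and compound 2. The step expected here is a step that the limit leaves unreadable from compound 3 to compound 4, an expectation that rests on the earlier step having been a 1.5-fold lower number from compound 1 to compound 2 (0.17 log units; within the scatter), small enough to lie within the usual scatter. Compound 4 is therefore expected to give 110 mg/kg in this assay, with the estimate spanning from 55 mg/kg to 250 mg/kg, and a real chance that only a limit is reported again.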

Compound 4, dose for half-maximal effect: 80 mg/kg
The estimate for compound 4 lay 1.4-fold (0.14 log units) above the measured number, within the range that was stated.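

On the core of compound 3, methyl in place of hydrogen on an aromatic carbon brought an at least 1.2-fold lower number from compound 3 to compound 4 (0.09 log units; that floor lies within the scatter), which shows that the change can be carried to this second core and that compound 4 gives a number within the range of this assay, but it does not show a lowering by any real margin. Compound 3 gives > 100 mg/kg, and this is a limit of the assay, not a number. Whether the change does the same on both cores therefore stays unsettled: the same change on two cores in this assay, a 1.5-fold lower number (0.17 log units; within the scatter) from compound 1 to compound 2 and an at least 1.2-fold lower number (0.09 log units; that floor lies within the scatter) from compound 3 to compound 4; the limit leaves it open whether they differ.

The compounds shown carry only hydrogen or methyl on this aromatic carbon, so it remains open how an ethyl group, a longer chain or a chlorine atom would read there. As far as these compounds go, it also remains open whether the step would hold on a third core, for instance one with a simple amine in place of the carbonyl-bearing group.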